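Swapping pyridin-3-yl for thiophen-2-yl in compound 1

A few compounds are considered here, and "the series" means these few. Any claim that something is new, unique, unknown or untested is made for them only; others in the source may bear on it.

Measured so far in a functional assay on MGC-803 cells (Homo sapiens) for antiproliferative activity, read by MTT assay, with a stated time of 72 h; a higher number here means a weaker inhibitor, a lower number a stronger inhibitor
Compound 1 `CCCSc1nc(N/N=C/c2cccnc2)c2nnn(Cc3ccccc3)c2n1` gives 38100 nM 
Compound 2 `C#CCSc1nc(N/N=C/c2ccc(N(C)C)cc2)c2nnn(Cc3ccccc3)c2n1` gives 7620 nM 
Compound 3 `CCCSc1nc(N/N=C(\C)c2ccccc2O)c2nnn(Cc3ccccc3Cl)c2n1` gives 35000 nM 

Compound 1 and compound 3 lie within the usual scatter of each other, so they count as level at the high end of these numbers. Compound 2 has a clearly lower number, beyond that scatter.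

Compound 4 `CCCSc1nc(N/N=C/c2cccs2)c2nnn(Cc3ccccc3)c2n1` keeps the rest of compound 1 but carries thiophen-2-yl in place of pyridin-3-yl on a carbon with a double bond to nitrogen.

Among the compounds with values here, no two measured compounds differ in one place only, so the data hold no direct measure of such a swap. Compound 2 at 7620 nM shows that lower numbers occur in this small set, yet it differs from compound 1 in more than one place. In this assay a small step toward a lower number is expected, probably within the scatter. The estimated step is a 1.7-fold lower number from compound 1 to compound 4 (0.24 log units; within the scatter) and no larger change is expected. For compound 4 the expected value is 22000 nM with an estimated range from 9000 nM to 50000 nM as the likely span.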

Compound 4, half-maximal inhibitory concentration: > 64000 nM
Compound 4: no number, only a limit (the forecaster's own chance of this, stated with the estimate: 8%); at least 2.9-fold (0.46 log units) between middle value and limit.
By their numbers in this assay, from the lowest: compound 2; then compounds 3 and 1 (each within the scatter of the next). At a limit, above all of these: compound 4.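

In this assay compound 4 gives > 64000 nM, which is a limit of the assay and not a number. Within the data shown here, this is the first direct measure of a change on a carbon with a double bond to nitrogen: thiophen-2-yl in place of pyridin-3-yl gives an at least 1.6-fold higher number from compound 1 to compound 4 (0.22 log units; that floor lies within the scatter), so this five-membered ring brought no sign of a lower number, although the true size of the step stays unknown. Only one compound shown gives such a reading: the limit of > 64000 nM in this assay, at which 1 of the 4 values shown sits.

Going by these compounds, whether a furan-2-yl or a pyridin-4-yl on this carbon would stay level with compound 1 or move towards compound 4 remains open. On these data alone, it is also open whether the same swap would have a similar effect on the rest of compound 2, which carries a different chain on sulfur.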